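The compounds below may be only part of what the source reports. "The series", "measured", "known", "first", "only" and "open" are said of these compounds alone.

Measured compounds, values in an assay on THP-1 cells for antagonist activity at P2X purinoceptor 7 (Homo sapiens), read by ELISA, with a stated time of 30 min; on this read-out lower numbers stand for stronger inhibition and higher numbers for weaker inhibition:
- compound 1 `CN(C)c1ccc(C(=O)N2CCC(n3cncc3-c3ccc(OS(=O)(=O)c4cccc5cnccc45)cc3)CC2)cc1`: 2.19 nM
- compound 2 `CS(=O)(=O)c1ccc(C(=O)N2CCN(c3cc(=O)[nH]c(=O)n3Cc3ccc(OS(=O)(=O)c4cccc5cnccc45)cc3)CC2)cc1`: 50 nM
- compound 3 `O=C(c1ccc(Cl)c(C(F)(F)F)c1)N1CCC(c2nc3cc(OS(=O)(=O)c4cccc5cnccc45)ccc3[nH]2)CC1`: 210 nM

Compound 3 stands at the highest of the three numbers in this assay. Compound 2 gives the nearest value, lower and beyond the scatter; compound 1 gives the lowest value of the three, far below compound 3 and likewise beyond the scatter. For the measured compounds named here, the three compounds differ in more than one place, so no single-site step between measured compounds is available.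

Compound 4 `O=C(c1ccc([N+](=O)[O-])cc1)N1CCC(c2nc3cc(OS(=O)(=O)c4cccc5cnccc45)ccc3[nH]2)CC1` is the next compound for this assay. It differs from compound 3 in one place: 4-nitrophenyl in place of 4-chloro-3-(trifluoromethyl)phenyl on a carbonyl carbon. No measured pair shows this change or one close to it, so the size and direction of the step rest on no shown step. The working expectation is a step from compound 3 to compound 4 of a 1.3-fold higher number from compound 3 to compound 4 (0.12 log units; within the scatter), which is within the scatter or a little beyond it toward a higher number. Compound 4 is accordingly expected to give about 280 nM, with a range from 80 nM to 1000 nM.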

Compound 4, half-maximal inhibitory concentration: 17 nM
Beside the measured number, compound 4's estimate is 16-fold (1.22 log units) above it, outside the stated range (below it).
By their numbers in this assay, from the lowest: compound 1; then compound 4; then compound 2; then compound 3.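

The aryl group on the carbonyl carbon bound to the ring amide-type nitrogen strongly affects the read-out in this assay: 4-nitrophenyl in place of 4-chloro-3-(trifluoromethyl)phenyl gives a 12-fold lower number from compound 3 to compound 4 (1.09 log units; beyond the scatter). The chlorine and the trifluoromethyl are therefore not needed for a low number on this core, and the entering group carries hydrogen-bond acceptors that the leaving group lacks, although a single pair cannot separate these differences. No measurement bearing on the reason for the step is available.

On these data alone, whether the step follows from adding the nitro group or from removing the chlorine or the trifluoromethyl remains open. Also open, as far as these compounds go, is how an unsubstituted phenyl, a 4-aminophenyl or a 4-carboxyphenyl would read at this position, and whether 4-nitrophenyl would have a similar effect on the core of compound 1.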